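A few compounds are considered here, and "the series" means these few. Any claim that something is new, unique, unknown or untested is made for them only; others in the source may bear on it.

Compound 1 `CCC(C(=O)N[C@@H](CC(=O)O)C(=O)CSCc1ccccc1)n1ccnc(NCc2cncs2)c1=O` sets the shared core, and in an assay for inhibition of Caspase-8 (Homo sapiens) (on this read-out lower numbers stand for stronger inhibition and higher numbers for weaker inhibition), compound 1 gives 6590 nM. For the measured compounds named here, compound 2 `CCC(C(=O)N[C@@H](CC(=O)O)C(=O)CSCc1ccccc1)n1ccnc(NCCCOC)c1=O` replaces the ring of compound 1 with a chain; in this assay compound 2 gives 7650 nM, the higher of the two numbers so far, although the step of a 1.2-fold higher number from compound 1 to compound 2 (0.06 log units; within the scatter) lies within the scatter. Compound 3 `CCC(C(=O)N[C@@H](CC(=O)O)C(=O)CSCc1ccccc1)n1ccnc(NCc2nc(C)no2)c1=O` has not yet been measured. It differs from compound 2 by 3-methyl-1,2,4-oxadiazol-5-yl in place of 2-methoxyethyl on a saturated chain carbon bound to a nitrogen on an aromatic ring. Going by the values given here, only one measured step touches this place: a 1.2-fold higher number from compound 1 to compound 2 (0.06 log units; within the scatter), in which a five-membered aromatic ring gave way to a chain without any movement beyond the scatter. Compound 3 puts a five-membered aromatic ring back in that place, so for compound 3 no step beyond the scatter is expected in this assay. Compound 3 is estimated at 6800 nM, with a range from 3000 nM to 15000 nM. The expected step is therefore a 1.1-fold lower number from compound 2 to compound 3 (0.05 log units; within the scatter).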

Compound 3, half-maximal inhibitory concentration: 6420 nM
Beside the measured number, compound 3's estimate is 1.1-fold (0.02 log units) above it; low and high end bracket the measured number.
By their numbers in this assay, from the lowest: compounds 3, 1 and 2 (each within the scatter of the next).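

In this assay, the change to 3-methyl-1,2,4-oxadiazol-5-yl gives a 1.2-fold lower number from compound 2 to compound 3 (0.08 log units; within the scatter) and a 1.0-fold lower number from compound 1 to compound 3 (0.01 log units; within the scatter), so a second five-membered aromatic ring at this place, on a saturated chain carbon bound to a nitrogen on an aromatic ring, stays within the scatter of both the chain and the 1,3-thiazol-5-yl group. Going from 2-methoxyethyl to this ring takes the group from 4 to 6 heavy atoms and from 1 to 3 hydrogen-bond acceptors, and no step beyond the scatter comes with it. Nothing available explains why these three groups do not separate.

The compounds shown leave open whether an amine, a carboxylic acid or a longer chain at this place would give a step beyond the scatter. They also leave open whether a six-membered ring such as phenyl would behave like the five-membered rings.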